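A Side Chain Swap on a Shared Core

The compounds below may be only part of what the source reports. "The series", "measured", "known", "first", "only" and "open" are said of these compounds alone.

Measured in a functional assay on A549 cells (Homo sapiens) for cytotoxicity, read by MTT assay, with a stated time of 72 h (on this read-out lower numbers stand for stronger inhibition and higher numbers for weaker inhibition), and listed by compound
- Compound 1 `O=C1c2c[n+]([O-])c3ccccc3c2C(=O)c2c1c1ccccc1n2CCCCn1ccnc1` gives 170 nM
- Compound 2 `CN1CCN(CCCCCCn2c3c(c4ccccc42)C(=O)c2c[n+]([O-])c4ccccc4c2C3=O)CC1` gives 330 nM

Among the compounds with values here, compound 2 at 330 nM stands level, within the scatter, with the only other compound measured. Within the data shown here, compound 3 `O=C1c2c[n+]([O-])c3ccccc3c2C(=O)c2c1c1ccccc1n2CCCN1CCC(O)CC1` has no measurement yet. The change from compound 2 reads 4-hydroxypiperidin-1-yl in place of 3-(4-methylpiperazin-1-yl)propyl on a saturated chain carbon, three bonds along the chain from an aromatic nitrogen or, in words, 4-hydroxypiperidin-1-yl in place of 3-(4-methylpiperazin-1-yl)propyl on a saturated chain carbon, three bonds along the chain from an aromatic nitrogen.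

Among the measured compounds shown here, one measured step bears on this, a 1.9-fold higher number from compound 1 to compound 2 (0.29 log units; within the scatter) and it too swapped a group on a saturated chain carbon. With that single step inside the scatter, no step beyond the scatter is expected in this assay here, in either direction. What is expected is a 1.3-fold lower number from compound 2 to compound 3 (0.10 log units; within the scatter) and nothing larger. For compound 3 the estimate is 260 nM with an expected range from 100 nM to 650 nM around it.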

Compound 3, half-maximal inhibitory concentration: 350 nM
For compound 3 the middle estimate is 1.3-fold (0.13 log units) below the measured one, within the range that was stated.
By their numbers in this assay, from the lowest: compounds 1, 2 and 3 (each within the scatter of the next, the first and the last beyond it).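

In this assay the swap at this place, on a saturated chain carbon, three bonds along the chain from an aromatic nitrogen, gives a 1.1-fold higher number from compound 2 to compound 3 (0.03 log units; within the scatter) and so leaves the reading unmoved, even though 4-hydroxypiperidin-1-yl and 3-(4-methylpiperazin-1-yl)propyl differ in size and in their ring. The one step beyond the scatter among these compounds is a 2.1-fold higher number from compound 1 to compound 3 (0.31 log units; beyond the scatter) and it is modest, with compound 2 within the scatter of both of the others. Nothing given here explains why the numbers fall as they do.

A morpholin-4-yl group or a primary amine on this chain lies outside the compounds shown, so how either would read in this assay remains open. Also open, on these data alone, is what the hydroxyl contributes, since plain piperidin-1-yl is not among them.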